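A few compounds are considered here, and "the series" means these few. Any claim that something is new, unique, unknown or untested is made for them only; others in the source may bear on it.

Three compounds share one core. In an assay on microsomes from intestine for inhibition of acyl-CoA:cholesterol acyltransferase (Oryctolagus cuniculus) (on this read-out lower numbers stand for stronger inhibition and higher numbers for weaker inhibition), compound 1 `COc1ccc(NC(=O)NCC2(c3ccccc3)CCCCC2)cc1` gives 4900 nM, compound 2 `Cc1ccc(NC(=O)NCC2(c3ccccc3)CCCCC2)cc1` gives 4500 nM, and compound 3 `O=C(NCC1(c2ccccc2)CCCCC1)Nc1ccc(I)cc1` gives 2300 nM. The steps between them were a 1.1-fold lower number from compound 1 to compound 2 (0.04 log units; within the scatter), a 2.1-fold lower number from compound 1 to compound 3 (0.33 log units; beyond the scatter) and a 2.0-fold lower number from compound 2 to compound 3 (0.29 log units; within the scatter); compound 3 thus stands beyond the scatter from compound 1, while its gap to compound 2 lies within it. Compound 4 `O=C(NCC1(c2ccccc2)CCCCC1)Nc1cc(Cl)ccc1Cl` differs from compound 3 by 2,5-dichlorophenyl in place of 4-iodophenyl on an amide-type nitrogen. Within the data shown here, no measured step covers this change: all three vary a single group on an aromatic carbon, and the larger of them was only modest. The step is therefore expected to be a 1.1-fold higher number from compound 3 to compound 4 (0.04 log units; within the scatter), small in either direction. Compound 4 is expected to give 2500 nM in this assay, between 800 nM and 8000 nM.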

Compound 4, half-maximal inhibitory concentration: 2700 nM
Beside the measured number, compound 4's estimate is 1.1-fold (0.03 log units) below it; the range from low to high includes it.
By their numbers in this assay, from the lowest: compounds 3, 4, 2 and 1 (each within the scatter of the next, the first and the last beyond it).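

In this assay, the exchange of one substituent for two on the ring at the amide-type nitrogen gives a 1.2-fold higher number from compound 3 to compound 4 (0.07 log units; within the scatter), so 2,5-dichlorophenyl and 4-iodophenyl cannot be told apart at this position. The comparisons a 1.7-fold lower number from compound 2 to compound 4 (0.22 log units; within the scatter) and a 1.8-fold lower number from compound 1 to compound 4 (0.26 log units; within the scatter) also stay within the scatter, so this position tolerates the new substitution pattern without a clear change in the number. No measurement here offers an explanation for this result.

The compounds leave open what each chlorine contributes, since none carries a single chlorine. As far as these compounds go, it also remains open whether an amine, a carboxylic acid or a longer chain at this position would move the number beyond the scatter.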